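Aryl substituent swaps on the benzylthio arm: compound 4

The compounds below may be only part of what the source reports. "The series", "measured", "known", "first", "only" and "open" are said of these compounds alone.

Measured so far in an assay on isolated protein for inhibition of Equilibrative nucleoside transporter 1 (Homo sapiens); a higher number here means a weaker inhibitor, a lower number a stronger inhibitor:
compound 1 `OC[C@H]1O[C@@H](n2cnc3c(SCc4ccc(Br)cc4)ncnc32)[C@H](O)[C@@H]1O`, 11.5 nM
compound 2 `OC[C@H]1O[C@@H](n2cnc3c(SCc4ccccc4I)ncnc32)[C@H](O)[C@@H]1O`, 19.5 nM
compound 3 `OC[C@H]1O[C@@H](n2cnc3c(SCc4cccc(C(F)(F)F)c4)ncnc32)[C@H](O)[C@@H]1O`, 19.1 nM

Compound 3 holds the second highest of the three numbers. Its nearest neighbour is compound 2, separated by a 1.0-fold lower number from compound 2 to compound 3 (0.01 log units; within the scatter), and its furthest is compound 1, separated by a 1.7-fold higher number from compound 1 to compound 3 (0.22 log units; within the scatter); both gaps sit inside the scatter, so no order among the three can be read from these values.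

Compound 4 `OC[C@H]1O[C@@H](n2cnc3c(SCc4ccc(Cl)cc4Cl)ncnc32)[C@H](O)[C@@H]1O` is not yet measured. It differs from compound 3 in one place: 2,4-dichlorophenyl in place of 3-(trifluoromethyl)phenyl on a saturated chain carbon bound to a sulfur.

Going by the values given here, the steps that bear on this change are the two that also exchange one substituted phenyl for another on the same saturated chain carbon bound to a sulfur: a 1.7-fold higher number from compound 1 to compound 3 (0.22 log units; within the scatter) and a 1.0-fold lower number from compound 2 to compound 3 (0.01 log units; within the scatter), together with a 1.7-fold higher number from compound 1 to compound 2 (0.23 log units; within the scatter). Each of these lies within the scatter. Three such swaps, none of which moved the number beyond the scatter, give no ground to expect anything different for a fourth.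

The expected step in this assay is therefore a 1.2-fold lower number from compound 3 to compound 4 (0.08 log units; within the scatter), that is, no move beyond the scatter in either direction. On that basis compound 4 is estimated at 16 nM, with a range from 6 nM to 45 nM.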

Compound 4, inhibition constant: 4.37 nM
The estimate for compound 4 lay 3.7-fold (0.56 log units) above the measured number; the measured number lies below the stated range.
By their numbers in this assay, from the lowest: compound 4; then compounds 1, 3 and 2 (each within the scatter of the next).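

In this assay, going by these compounds alone, compound 4 is the first member of the series to separate from the others, with all three steps beyond the scatter and all running to the lower number: (a 4.4-fold lower number from compound 3 to compound 4 (0.64 log units; beyond the scatter)) and (a 4.5-fold lower number from compound 2 to compound 4 (0.65 log units; beyond the scatter)) and (a 2.6-fold lower number from compound 1 to compound 4 (0.42 log units; beyond the scatter)). Within the data shown here, the number at this saturated chain carbon bound to a sulfur therefore does respond to the choice of aryl group, which compounds 1, 2 and 3 could not show, as they sit within the scatter of one another and 2,4-dichlorophenyl is the only group among the four with two substituents on the ring. Nothing measured here accounts for the lower number of compound 4.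

Open, going by these compounds, is whether 2-chlorophenyl or 4-chlorophenyl alone would reach the number of compound 4, or whether both chlorines are needed. Also open, on these data alone, is how far this place accepts something other than a halogen-bearing phenyl, such as a phenyl carrying an amine or a carboxylic acid, or a longer chain between the sulfur and the ring.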